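The source may report more compounds than this note shows. Statements on the series, on what has been measured and on what is new or still open speak of the compounds shown alone.

Working notes on the series. Among the measured compounds shown here, compound 2 `COC(=O)CC1c2ccccc2N=C(NCCCCCNC(=O)OC(C)(C)C)N1c1ccc(-c2ccccc2)cc1` gives 4310 nM in a functional assay on SK-MEL-2 cells (Homo sapiens) for inhibition, read by sulforhodamine B assay, with a stated time of 72 h (on this read-out lower numbers stand for stronger inhibition of growth and higher numbers for weaker inhibition of growth), the highest of the two numbers so far; compound 1 `CC(C)(C)OC(=O)NCCCCCNC1=Nc2ccccc2C(CC(=O)NCc2ccccc2)N1c1ccccc1` gives 2020 nM in this assay, the nearest number, which is beyond the scatter. Compound 3 `CC(C)(C)OC(=O)NCCCCCNC1=Nc2ccccc2C(CC(=O)NCc2ccccc2)N1c1ccc(-c2ccccc2)cc1` is not yet measured and differs from compound 2 by benzylamino in place of methoxy on a carbonyl carbon. No single-change step between measured compounds is known, so the direction is expected rather than shown. With compound 1 at 2020 nM carrying the same benzylcarbamoyl group, a modest step downward is expected, a 1.7-fold lower number from compound 2 to compound 3 (0.24 log units; within the scatter). Compound 3 is estimated at 2500 nM, within 1000 nM to 6500 nM.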

Compound 3, concentration for 50% growth inhibition: 1480 nM
Beside the measured number, compound 3's estimate is 1.7-fold (0.23 log units) above it, within the range that was stated.
By their numbers in this assay, from the lowest: compounds 3 and 1 (each within the scatter of the next); then compound 2.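

In this assay, among the compounds shown here, benzylamino in place of methoxy on a carbonyl carbon gives a 2.9-fold lower number from compound 2 to compound 3 (0.46 log units; beyond the scatter), the first single-change step at this position, and it lies beyond the scatter. Phenyl in place of hydrogen on an aromatic carbon gives a 1.4-fold lower number from compound 1 to compound 3 (0.14 log units; within the scatter), which stays within the scatter, so this change has no readable effect here. Nothing measured on these compounds accounts for either step.

From the compounds shown here alone, whether the step at the carbonyl carbon follows the added ring or the amide hydrogen stays open. Methylamino or a carboxylic acid at that carbon would help separate the two.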